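A few compounds are considered here, and "the series" means these few. Any claim that something is new, unique, unknown or untested is made for them only; others in the source may bear on it.

Measured in a functional assay on HOS-TE85 cells (Homo sapiens) for inhibition, read by CCK-8 assay, with a stated time of 72 h; on this read-out lower numbers stand for stronger inhibition and higher numbers for weaker inhibition:
- compound 1 `COc1ccc(C)cc1N1C(=O)CSC1c1cccc(C(=O)NCCCCc2ccccc2)c1`: 300 nM
- compound 2 `COc1ccccc1N1C(=O)CSC1c1cccc(C(=O)NCCCCn2cncn2)c1`: > 1000 nM

In this assay, compound 2 stands at > 1000 nM, which is a limit and not a number. Compound 3 `COc1ccccc1N1C(=O)CSC1c1cccc(C(=O)NCCCCc2cccs2)c1` differs from it by thiophen-2-yl in place of 1H-1,2,4-triazol-1-yl on a saturated chain carbon, four bonds along the chain from an amide-type nitrogen. No measured step sizes this change. Going by the values given here, the only numerical reference is compound 1 at 300 nM. The expected step, an at least 2.5-fold lower number from compound 2 to compound 3 (0.39 log units; beyond the scatter), is moderate, towards stronger inhibition and just beyond the scatter. The estimate for compound 3 is 400 nM, with an expected range of 120 nM to 1000 nM.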

Compound 3, half-maximal inhibitory concentration: 46 nM
Beside the measured number, compound 3's estimate is 8.7-fold (0.94 log units) above it; measured number below the stated range.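

In this assay, this chain end proves highly sensitive to the identity of its ring: thiophen-2-yl in place of 1H-1,2,4-triazol-1-yl gives an at least 21-fold lower number from compound 2 to compound 3 (1.33 log units; beyond the scatter). Both groups are five-membered aromatic rings of 5 heavy atoms, so the change lies in the ring atoms, not in their count. The size of this step is only a bound, as the value of compound 2 is a limit and not a number: the limit of > 1000 nM in this assay, at which 1 of the 3 values shown sits.

Compound 1 differs from compound 3 in more than one place, so it does not show how a phenyl group compares with thiophen-2-yl on this chain. From the compounds shown here alone, whether a furan-2-yl or 1H-imidazol-1-yl group here would track compound 3 or compound 2 remains open.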